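Cutting the chain back from 2-cyanoethyl to methyl

The compounds below may be only part of what the source reports. "The series", "measured", "known", "first", "only" and "open" are said of these compounds alone.

In an ADME assay on MDCKII-LE cells (Canis lupus familiaris) for permeability, in the apical to basolateral direction (a higher number here means that the compound crosses the layer faster, a lower number that the compound crosses the layer more slowly), compound 2 `COc1ccc2c(c1O)CCCC(CCC#N)=C2c1cc(OC)c(OC)c(OC)c1` stands highest of the two measured compounds at 19.6 10^-6 cm/s and compound 1 `CCC1=C(c2cc(OC)c(OC)c(OC)c2)c2ccc(OC)c(O)c2CCC1` sits lower at 3.3 10^-6 cm/s on the same scale. Compound 3 `COc1ccc2c(c1O)CCCC(C)=C2c1cc(OC)c(OC)c(OC)c1` differs from compound 2 by hydrogen in place of cyanomethyl on a saturated chain carbon bound to a double-bonded ring carbon and the same difference reads 2-cyanoethyl to methyl. Among the compounds with values here, the one measured step that bears on it is a 5.9-fold higher number from compound 1 to compound 2 (0.77 log units; beyond the scatter) with cyano in place of hydrogen on the chain, and compound 3 likewise carries no cyano. In this assay a lower number is therefore expected, with a 4.9-fold lower number from compound 2 to compound 3 (0.69 log units; beyond the scatter) as the estimated step, close in size to that one. Compound 3 is estimated at 4 10^-6 cm/s with an expected range from 1.5 10^-6 cm/s to 10 10^-6 cm/s in all.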

Compound 3, apparent permeability: 6.2 10^-6 cm/s
Compound 3: middle estimate off by 1.6-fold (0.19 log units), on the low side, within the range that was stated.
By their numbers in this assay, from the lowest: compounds 1 and 3 (each within the scatter of the next); then compound 2.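

In this assay, hydrogen in place of cyanomethyl gives a 3.2-fold lower number from compound 2 to compound 3 (0.50 log units; beyond the scatter), so among these compounds the higher number stays with compound 2, the only one carrying the nitrile. On the same saturated chain carbon, hydrogen in place of methyl gives a 1.9-fold higher number from compound 1 to compound 3 (0.27 log units; within the scatter), so this change in the length of the plain chain does not separate the two compounds without a nitrile. Nothing available here explains either step.

Going by these compounds, it remains open whether the nitrile is needed or whether a longer chain without it, such as propyl, would match compound 2. Chains ending in an amine or a carboxylic acid also remain open.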